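A few compounds are considered here, and "the series" means these few. Any claim that something is new, unique, unknown or untested is made for them only; others in the source may bear on it.

Compounds measured so far:

- compound 1, `Oc1ccc(F)cc1/C=N/c1ccc(OCc2ccccc2)cc1`: 15300 nM
- compound 2, `Oc1ccc(/C=N/c2ccc(OCc3ccccc3)cc2)c(O)c1O`: 1730 nM
- compound 3, `Oc1cc(O)c(/C=N/c2ccc(OCc3ccccc3)cc2)c(O)c1`: 10100 nM

Of the compounds shown here, three sharing one core have been tested in an assay on isolated protein for inhibition of Amine oxidase [flavin-containing] B (Homo sapiens), read by fluorescence and Amplex Red, with stated times of 15 min and 20 min; on this read-out higher numbers stand for weaker inhibition and lower numbers for stronger inhibition. Compound 1 gives 15300 nM, the highest number of the three. Its nearest neighbour on the numbers is compound 3, whose value of 10100 nM lies within the scatter of that of compound 1, so the two cannot be placed in order. Compound 2, with 1730 nM, stands beyond the scatter from compound 1 and so is a stronger inhibitor than compound 1 on this read-out.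

Compound 4, `Oc1ccc(Cl)cc1/C=N/c1ccc(OCc2ccccc2)cc1`, has not yet been measured in this assay . It differs from compound 1 in one place: chloro in place of fluoro on an aromatic carbon.

For the measured compounds named here, no pair of measured compounds differs by this change, so there is no measured step to lean on. The expectation here is a step from compound 1 to compound 4 of small size, if any, toward a lower number, and most likely one that stays within the scatter: a 1.5-fold lower number from compound 1 to compound 4 (0.18 log units; within the scatter) is the step this estimate means. On that basis compound 4 is expected to give about 10000 nM in this assay , with a range from 4000 nM to 30000 nM.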

Compound 4, half-maximal inhibitory concentration: 24800 nM
Beside the measured number, compound 4's estimate is 2.5-fold (0.39 log units) below it; measured number inside the range.
By their numbers in this assay, from the lowest: compound 2; then compounds 3, 1 and 4 (each within the scatter of the next, the first and the last beyond it).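

In this assay, chloro in place of fluoro, para to a hydroxy group and meta to a large group, gives a 1.6-fold higher number from compound 1 to compound 4 (0.21 log units; within the scatter), a step within the usual scatter, so the two compounds cannot be placed in order. This is the only measured step at this position among the compounds shown, and it shows that on the shared core, the two halogens cannot be told apart on this read-out. Nothing measured here bears on why the step is this size.

Open, as far as these compounds go, is whether a group of another kind at this position, such as a methoxy, a nitrile or an amine, or simply hydrogen, would move the number beyond the scatter, since a single exchange of one halogen for another says little about those. For the compounds shown here, also open is which feature of compound 2 goes with its lower number, as it differs from compound 1 in more than one place and no single step connects the two.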